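Cyano to nitro in an antiproliferative series

This account rests on a few compounds, and the source may have more. Where it says the series, first, only, none or still open, it means among the compounds named here.

Compound 1 `CC(O)(CSc1cccc(OC(F)(F)F)c1)C(=O)Nc1cccc(S(F)(F)(F)(F)F)c1` gives 18700 nM
Compound 2 `CC(O)(COc1ccc(S(F)(F)(F)(F)F)cc1)C(=O)Nc1ccc(C#N)c(C(F)(F)F)c1` gives 28200 nM

In a functional assay on CWR22R cells (Homo sapiens) for antiproliferative activity, read by propidium iodide staining, with a stated time of 96 h (a higher number here means a weaker inhibitor, a lower number a stronger inhibitor), compound 2 stands at 28200 nM and compound 1 stands at 18700 nM and these two values lie within the usual scatter of each other. Neither compound can therefore be ranked over the other. Within the data shown here, the two compounds differ in more than one place, so they offer no measured step for a single change.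

The next compound, compound 3 `CC(O)(COc1ccc(S(F)(F)(F)(F)F)cc1)C(=O)Nc1ccc([N+](=O)[O-])c(C(F)(F)F)c1`, has yet to be measured. It keeps the rest of compound 2 and carries nitro in place of cyano on an aromatic carbon at a place ortho to a trifluoromethyl group and para to a large group.

Nothing in these data compares the two groups directly, so the expectation starts from compound 2 at 28200 nM and assumes no clear shift in either direction. The estimated change is a 1.1-fold lower number from compound 2 to compound 3 (0.05 log units; within the scatter) and it is expected to stay within the scatter. For compound 3 the estimated value is 25000 nM with an expected range from 9000 nM to 60000 nM in this wide band.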

Compound 3, half-maximal inhibitory concentration: 14100 nM
Compound 3: the middle estimate sits 1.8-fold (0.25 log units) above what was measured; the range from low to high includes it.
By their numbers in this assay, from the lowest: compounds 3, 1 and 2 (each within the scatter of the next).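

In this assay, among these compounds, the exchange of cyano for nitro, on the aromatic carbon ortho to a trifluoromethyl group and para to a large group, gives a 2.0-fold lower number from compound 2 to compound 3 (0.30 log units; within the scatter) and is the only single change that can be read in this set. It shows that at this position, with the rest of compound 2 kept, a nitro group of three heavy atoms can stand in place of a cyano group of two without the number leaving the scatter, so the two groups cannot be ranked here. No measurement bearing on the reason for this result is available.

The compounds shown leave open whether an amine or a carboxylic acid on the same aromatic carbon would also keep the number within the scatter of compound 2. They also leave open whether the nitro and cyano groups would still read alike if a chlorine atom took the place of the trifluoromethyl group, or if a sulfur atom took the place of the ether oxygen in the side chain.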